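This account rests on a few compounds, and the source may have more. Where it says the series, first, only, none or still open, it means among the compounds named here.

In an ADME assay on HEK-293T cells (Homo sapiens) for cytotoxicity, read by CCK-8 assay, with a stated time of 48 h (a lower number here means a stronger inhibitor, a higher number a weaker inhibitor), compound 2 `O=C(NCCNS(=O)(=O)c1ccc(-c2ccccc2OCc2ccccc2)s1)Nc1cccc([N+](=O)[O-])c1` gives 13300 nM. Compound 1 `O=[N+]([O-])c1cccc(NC(=S)NCCNS(=O)(=O)c2ccc(-c3ccccc3OCc3ccccc3)s2)c1` gives 18300 nM, so the two measured compounds stand level within the scatter. Compound 3 `O=S(=O)(NCCNC(=S)Nc1ccc(Cl)cc1)c1ccc(-c2ccccc2OCc2ccccc2)s1` keeps the core of compound 2 and changes only the group on an amine nitrogen whose other neighbours are a saturated chain carbon: a group of 10 heavy atoms (7 carbon, 1 nitrogen, 1 sulfur, 1 chlorine; one six-membered aromatic ring of carbon only) in place of a group of 12 heavy atoms (7 carbon, 2 nitrogen, 3 oxygen; one six-membered aromatic ring of carbon only), on an amine nitrogen. The entering group contains sulfur, as does the matching group in compound 1. Going by the values given here, only one measured step bears on this change: a 1.4-fold lower number from compound 1 to compound 2 (0.14 log units; within the scatter). That step exchanged a group at the same nitrogen and stayed within the scatter. Among the compounds with values here, no measured compound shows what the chlorine brings in place of the nitro group, so the expectation remains loose, and no step beyond the scatter is expected. The expected step is a 1.1-fold lower number from compound 2 to compound 3 (0.04 log units; within the scatter). For compound 3 the estimated value is 12000 nM, with an expected range from 5500 nM to 27000 nM.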

Compound 3, half-maximal inhibitory concentration: 12100 nM
The estimate for compound 3 lay 1.0-fold (0.00 log units) below the measured number, and the stated range covers the measured number.
By their numbers in this assay, from the lowest: compounds 3, 2 and 1 (each within the scatter of the next).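

In this assay, going by these compounds alone, the exchange of 3-nitrophenyl for 4-chlorophenyl on an amide-type nitrogen, with the sulfur of the linking group kept, gives a 1.5-fold lower number from compound 1 to compound 3 (0.18 log units; within the scatter) and so shows the first change of the aromatic group alone at this place, without a step beyond the scatter. The wider exchange on the amine nitrogen, which alters both that aromatic group and the carbonyl, gives a 1.1-fold lower number from compound 2 to compound 3 (0.04 log units; within the scatter) and also stays within the scatter, so all three compounds stand level. No measurement shown here accounts for this level standing.

The compounds shown leave open whether a group without an aromatic ring on this nitrogen, such as a plain alkyl chain, would give a step beyond the scatter. The same question stands for a phenyl ring carrying a carboxylic acid or an amine.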